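The source may report more compounds than this note shows. Statements on the series, on what has been measured and on what is new or still open speak of the compounds shown alone.

Three compounds have been measured in a functional assay, read by spectrophotometry, with a stated time of 30 min; a higher number here means a weaker inhibitor, a lower number a stronger inhibitor:

Compound 1 `Cc1c(C)c2c(c(C)c1O)CCC(C)(CO)O2` gives 3580 nM.
Compound 2 `C=COC(=O)CCCCCCCCCCC(=O)OC[C@H]1Oc2ccc([C@H]3Oc4cc(O)cc(O)c4C(=O)[C@@H]3O)cc2O[C@@H]1c1ccc(O)c(OC)c1` gives 372000 nM.
Compound 3 `COc1cc([C@H]2Oc3cc([C@H]4Oc5cc(O)cc(O)c5C(=O)[C@@H]4O)ccc3O[C@@H]2COC(=O)CCCCCCCCCCC(=O)OC[C@H](O)[C@H]2OC(=O)C(O)=C2O)ccc1O` gives 20600 nM.

Compound 3 stands second highest of the three numbers in this assay; compound 1 has a lower number and compound 2 a higher one, both gaps beyond the scatter. Among the compounds with values here, the one step measured on a single change is an 18-fold lower number from compound 2 to compound 3 (1.26 log units; beyond the scatter), which shows that the group on the oxygen next to the carbonyl group matters strongly in this assay.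

Compound 4 `COc1cc([C@H]2Oc3cc([C@H]4Oc5cc(O)cc(O)c5C(=O)[C@@H]4O)ccc3O[C@@H]2COC(=O)CCCCCCCCCCC(=O)OCCc2ccc(O)cc2)ccc1O` differs from compound 3 by a group of 8 heavy atoms (7 carbon, 1 oxygen; one six-membered aromatic ring of carbon only) in place of a group of 10 heavy atoms (5 carbon, 5 oxygen; one five-membered non-aromatic ring with 1 hetero atom), on a saturated chain carbon bound to an oxygen next to a carbonyl group. The step from compound 2 to compound 3 bears on this only loosely, since the group that enters in compound 4 is neither of the two compared there. With compound 2 marking one end and compound 3 the other, compound 4 is expected to fall between them, a step of a 2.9-fold higher number from compound 3 to compound 4 (0.46 log units; beyond the scatter), beyond the scatter but well short of the distance to compound 2. The estimate for compound 4 in this assay is 60000 nM, with a range from 15000 nM to 250000 nM.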

Compound 4, half-maximal inhibitory concentration: 253000 nM
The estimate for compound 4 lay 4.2-fold (0.62 log units) below the measured number; the whole stated range lies below it.
By their numbers in this assay, from the lowest: compound 1; then compound 3; then compounds 4 and 2 (each within the scatter of the next).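

In this assay a 12-fold higher number from compound 3 to compound 4 (1.09 log units; beyond the scatter) shows that the lower number of compound 3 depends on the particular group that leaves here, since a six-membered aromatic ring in the form of 4-hydroxybenzyl on a saturated chain carbon bound to an oxygen next to a carbonyl group does not preserve it. With a 1.5-fold lower number from compound 2 to compound 4 (0.17 log units; within the scatter), 2-(4-hydroxyphenyl)ethyl and vinyl on an oxygen next to a carbonyl group cannot be told apart, so among these three compounds only the group in compound 3 stands out. Nothing available explains this difference.

The compounds shown leave open whether the five-membered non-aromatic ring or the rest of the group that leaves accounts for the number of compound 3. From the compounds shown here alone, how a carboxylic acid or an amine at this place would read in this assay also remains open.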